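Halogen swap on a pyridine-substituted azocane binder

A few compounds are considered here, and "the series" means these few. Any claim that something is new, unique, unknown or untested is made for them only; others in the source may bear on it.

Compound 1 `c1cncc(N2CCCNCCC2)c1` is the parent of this small series. In an assay on HEK293 cells for displacement of a labelled ligand from Neuronal acetylcholine receptor; alpha4/beta2 (Homo sapiens) (on this read-out lower numbers stand for stronger inhibition and higher numbers for weaker inhibition), compound 1 gives 0.891 nM. Compound 2 `Clc1cncc(N2CCCNCCC2)c1` carries a chloro in place of one aromatic hydrogen, and in this assay compound 2 gives 2 nM. Within the data shown here, the only step measured so far, a 2.2-fold higher number from compound 1 to compound 2 (0.35 log units; beyond the scatter), shows that adding the chloro weakened binding a little, beyond the usual scatter but not by much. Among the two numbers in hand, compound 2 therefore stands at the higher end, with compound 1 the only neighbour, at a number that is lower by that same modest step.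

Compound 3 `Brc1cncc(N2CCCNCCC2)c1` is the next change: bromo in place of chloro on an aromatic carbon. Among the measured compounds shown here, no measured step covers a chloro-to-bromo exchange directly; the one step that bears on this position, from compound 1 to compound 2, was modest in size. A halogen-for-halogen swap of this kind is expected to move the number little, so for compound 3 the expected step of a 1.3-fold higher number from compound 2 to compound 3 (0.10 log units; within the scatter) is small and close to the scatter. The estimate for compound 3 in this assay is 2.5 nM, with a range from 1 nM to 6 nM.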

Compound 3, half-maximal inhibitory concentration: 2.82 nM
For compound 3 the middle estimate is 1.1-fold (0.05 log units) below the measured one; low and high end bracket the measured number.
By their numbers in this assay, from the lowest: compound 1; then compounds 2 and 3 (each within the scatter of the next).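

In this assay the swap of bromo for chloro gives a 1.4-fold higher number from compound 2 to compound 3 (0.15 log units; within the scatter) and so stays within the scatter, which means that this assay does not tell these two halogens apart at this aromatic carbon. Compared directly with the parent, bromo in place of hydrogen gives a 3.2-fold higher number from compound 1 to compound 3 (0.50 log units; beyond the scatter) and lies beyond the scatter, so compound 3 joins compound 2 in showing a modest loss of binding relative to compound 1, and neither halogen goes against that pattern. Nothing in hand explains this shared result or links it to any feature of the halogens.

The compounds shown leave open whether fluoro or iodo would fit the same picture, and whether a group that is not a halogen, such as methoxy, nitrile or an amine, would keep the number close to that of compound 1 or move it further away. They also leave open what a chloro or bromo would do on a different carbon of the same ring, since both halogens here sit two atoms from the ring nitrogen.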